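This account rests on a few compounds, and the source may have more. Where it says the series, first, only, none or still open, it means among the compounds named here.

Compound 1 `CN1Cc2ccc(OCc3ccc([N+](=O)[O-])cc3)cc2[C@@H](O)C1` in an ADME assay on Vero cells (Chlorocebus sabaeus) for cytotoxicity, read by sulforhodamine B assay, with a stated time of 72 h (on this read-out lower numbers stand for stronger inhibition and higher numbers for weaker inhibition), gives > 50000 nM.
Compound 2 `Cc1ccccc1COc1ccc2c(c1)[C@@H](O)CN(C)C2` gives > 100000 nM.
Compound 3 `CN1Cc2ccc(OCCCc3ccccc3)cc2[C@@H](O)C1` gives > 50000 nM.

The value of compound 3 is a limit of this assay, not a number. The value of compound 1 is likewise a limit. The value of compound 2 is also a limit. Two of the three values sit at the limit of > 50000 nM in this assay, at which 2 of the 3 values shown sit, and the remaining one sits at the limit of > 100000 nM in this assay, at which 1 of the 3 values shown sits. So compound 3 stands where all three measured compounds stand: nothing in this assay separates it from compound 1 or compound 2, and no toxic effect on the cells was reached within the tested range.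

Compound 4 `CN1Cc2ccc(OCCCN3CCNCC3)cc2[C@@H](O)C1` has not yet been measured. It differs from compound 3 in one place: piperazin-1-yl in place of phenyl on a saturated chain carbon, three bonds along the chain from an oxygen on an aromatic ring. For the measured compounds named here, since no step between measured compounds has been recorded, there is no measured step to lean on. The expectation is that the step from compound 3 to compound 4, a step that the limit leaves unreadable from compound 3 to compound 4, stays within the scatter, with no toxicity reached. Compound 4 is therefore estimated at 80000 nM, within a range from 40000 nM to 200000 nM, most likely reported again as a limit rather than a number.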

Compound 4, half-maximal inhibitory concentration: > 100000 nM
Compound 4 gave a limit, no number (the forecaster's own chance of this, stated with the estimate: 85%); middle value at least 1.2-fold (0.09 log units) from the limit.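

Compound 3 and compound 4 both sit at limits of the assay rather than at numbers, so the size of the step from phenyl to piperazin-1-yl cannot be read. The compounds shown leave open at what concentration, if any, any of them would become toxic to the cells in this assay.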